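Amide to acid on the naphthylpyridine acrylamide series

The source may report more compounds than this note shows. Statements on the series, on what has been measured and on what is new or still open speak of the compounds shown alone.

Measured compounds in a functional assay on MDA-MB-231 cells (Homo sapiens) for inhibition, read by sulforhodamine B assay, with a stated time of 72 h; on this read-out higher numbers stand for weaker inhibition of growth and lower numbers for stronger inhibition of growth:
Compound 1, `COC1CN(C(=O)/C=C/c2ccncc2-c2ccc3ccccc3c2)C1`: > 10000 nM
Compound 2, `CNC(=O)CCc1ccncc1-c1ccc2ccccc2c1`: 8980 nM
Compound 3, `O=C(/C=C/c1ccncc1-c1ccc2ccccc2c1)NC1CC1`: 8420 nM

Compound 1, `COC1CN(C(=O)/C=C/c2ccncc2-c2ccc3ccccc3c2)C1`, reaches only the limit of this assay, > 10000 nM. Compound 2, `CNC(=O)CCc1ccncc1-c1ccc2ccccc2c1`, gives 8980 nM in this assay. Compound 3, `O=C(/C=C/c1ccncc1-c1ccc2ccccc2c1)NC1CC1`, gives 8420 nM, the lowest of the two numbers, with compound 2 nearest and within the scatter of it.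

The two measured steps into compound 3 are both small: an at least 1.1-fold lower number from compound 1 to compound 3 (0.07 log units; that floor lies within the scatter), and a 1.1-fold lower number from compound 2 to compound 3 (0.03 log units; within the scatter). Both change the group on the carbonyl carbon or the linker while keeping an amide, and neither moves the growth inhibition beyond the scatter.

Compound 4, `O=C(O)/C=C/c1ccncc1-c1ccc2ccccc2c1`, differs from compound 3 as follows: hydroxy in place of cyclopropylamino on a carbonyl carbon. Going by the values given here, no measured pair here exchanges an amide for a carboxy group, so the two steps above speak to this change only in showing that variation at the carbonyl carbon has so far stayed within the scatter. The account therefore expects compound 4 to sit near or beyond the limit seen for compound 1, (the limit of > 10000 nM in this assay, at which 1 of the 3 values shown sits), with an estimated step of a 1.8-fold higher number from compound 3 to compound 4 (0.25 log units; within the scatter).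

Compound 4 is expected to give about 15000 nM in this assay, within a range from 5000 nM to 40000 nM.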

Compound 4, concentration for 50% growth inhibition: > 10000 nM
Compound 4 gave a limit, no number; the forecaster's own chance of this, stated with the estimate: 60%; the middle value lies beyond the limit too.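

In this assay compound 4 gives > 10000 nM, which is a limit and not a number. The carboxy group takes the amide away from this carbonyl carbon altogether, with an at least 1.1-fold higher number from compound 3 to compound 4 (0.07 log units; that floor lies within the scatter), and the exchange of 2-(methylcarbamoyl)ethyl for 2-carboxyethenyl gives an at least 1.1-fold higher number from compound 2 to compound 4 (0.04 log units; that floor lies within the scatter); both floors lie within the scatter, so the carboxy group brings no gain over these amides, yet it is not shown to weaken growth inhibition either. The step between compound 1 and compound 4 cannot be read, because both compounds stand at the limit: the limit of > 10000 nM in this assay, at which 2 of the 4 values shown sit.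

What the compounds shown leave open is how far past the limit compound 4 lies, and whether a methyl ester or a primary amide on this carbonyl carbon would behave like the carboxy group or like the cyclopropyl amide. Also open, on these data alone, is whether a carboxy group on the saturated 2-carboxyethyl chain would read the same as on the 2-carboxyethenyl chain, since no readable step here yet lies beyond the scatter.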